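The source may hold more compounds than are shown below. What is called first, only, known or untested is meant among the compounds shown, and "the series" means these compounds.

In an ADME assay on MT4 cells (Homo sapiens) for cytotoxicity, read by MTT assay, with a stated time of 4 days (a lower number here means that less compound is tolerated, a higher number that more compound is tolerated), three compounds have been examined so far: compound 1 `CN(C)c1nc(Cc2c(F)cccc2F)cc(=O)[nH]1`, compound 2 `CN1CCN(c2nc(Cc3c(F)cccc3F)cc(=O)[nH]2)CC1` and compound 3 `Cc1c(Cc2c(F)cccc2F)nc(N(C)C)[nH]c1=O`. Compound 1 gives > 94000 nM, which is a limit of the assay. Compound 2 gives > 78000 nM, also a limit. Compound 3 gives > 89000 nM, again a limit, so it stands without a number, as do the other two.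

Compound 4 `CCCN(CCC)c1nc(Cc2c(F)cccc2F)c(C)c(=O)[nH]1` differs from compound 3 in one place: dipropylamino in place of dimethylamino on an aromatic carbon. Among the compounds with values here, two measured steps bear on this change. Exchanging dimethylamino for 4-methylpiperazin-1-yl is a step that the two limits leave unreadable from compound 1 to compound 2. Adding the methyl in place of hydrogen is a step that the two limits leave unreadable from compound 1 to compound 3. Neither step has a readable size, so they offer no measured guide to a shift in this assay, and nothing beyond the usual scatter is expected, with only a slight lean towards less compound being tolerated. The expected change is an at least 1.6-fold lower number from compound 3 to compound 4 (0.20 log units; that floor lies within the scatter). A result that is again only a limit would be no surprise. Compound 4 is expected at 55000 nM, with an estimated range of 15000 nM to 90000 nM.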

Compound 4, half-maximal cytotoxic concentration: > 74000 nM
Compound 4 gave a limit, no number; the forecaster's own chance of this, stated with the estimate: 55%; middle value at least 1.3-fold (0.12 log units) away from the limit.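

In this assay compound 4 gives > 74000 nM, which is a limit and not a number. Compound 3 also stands only at a limit, so the step between compound 3 and compound 4 cannot be read. The compounds shown leave open at what concentration any of them becomes cytotoxic.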